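Hydroxamate series: shortening the alkoxy chain of compound 1

The source may report more compounds than this note shows. Statements on the series, on what has been measured and on what is new or still open speak of the compounds shown alone.

The series is read in an assay on isolated protein for inhibition of protein deacetylase HDAC6 (Homo sapiens), read by fluorescence, with a stated time of 30 min; a higher number here means a weaker inhibitor, a lower number a stronger inhibitor. Compound 1 `COc1cc2c(NCC3CCN(Cc4ccc(C(=O)NO)cc4)CC3)cc(-c3ccc(C)o3)nc2cc1OCCCN1CCCC1` gives 53 nM, the lowest of the two numbers reported. Compound 2 `COc1cc2c(NCC3CCN(c4ccc(C(=O)NO)cc4)CC3)cc(-c3ccc(C)o3)nc2cc1OCCCN1CCCC1` gives 67 nM; the step of a 1.3-fold higher number from compound 1 to compound 2 (0.10 log units; within the scatter) is within the scatter, so the two are not separable. Compound 3 `COc1cc2c(NCC3CCN(C4CCC(C(=O)NO)CC4)CC3)cc(-c3ccc(C)o3)nc2cc1OCCCN1CCCC1` gives only a limit of the assay, > 20000 nM. The steps of an at least 370-fold higher number from compound 1 to compound 3 (2.57 log units; beyond the scatter) and an at least 290-fold higher number from compound 2 to compound 3 (2.47 log units; beyond the scatter) are both large, and the size of each is bounded by the limit of > 20000 nM in this assay, at which 1 of the 3 values shown sits.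

Compound 4 `COc1cc2nc(-c3ccc(C)o3)cc(NCC3CCN(Cc4ccc(C(=O)NO)cc4)CC3)c2cc1OC` differs from compound 1 at another position: hydrogen in place of 2-(pyrrolidin-1-yl)ethyl on a saturated chain carbon bound to an oxygen on an aromatic ring. Every measured step changes the group carrying the hydroxamic acid and leaves the alkoxy chain untouched, so none of them bears directly on this change, and nothing measured here speaks for a step beyond the scatter in either direction.

Compound 4 is therefore expected to stay close to compound 1, with an estimated value of 80 nM (range 30 nM to 300 nM), meaning an expected step of a 1.5-fold higher number from compound 1 to compound 4 (0.18 log units; within the scatter).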

Compound 4, half-maximal inhibitory concentration: 84 nM
For compound 4 the middle estimate is 1.1-fold (0.02 log units) below the measured one; the range from low to high includes it.
By their numbers in this assay, from the lowest: compounds 1, 2 and 4 (each within the scatter of the next). At a limit, above all of these: compound 3.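

Cutting the 3-(pyrrolidin-1-yl)propoxy group back to methoxy gives a 1.6-fold higher number from compound 1 to compound 4 (0.20 log units; within the scatter) in this assay, and this is the first reading at a position outside the group carrying the hydroxamic acid. With the 4-(hydroxycarbamoyl)benzyl group held constant, this position therefore accepts the loss of the whole 2-(pyrrolidin-1-yl)ethyl part with no change that can be separated from the scatter, although this rests on a single pair of compounds. Nothing measured here gives a reason for this outcome.

Still open, going by these compounds, is whether a shorter chain ending in a dimethylamino group, or a chain ending in a carboxylic acid, would also stay within the scatter of compound 1 at this position. On these data alone, it is equally open whether methoxy would behave the same way alongside the 4-(hydroxycarbamoyl)phenyl group of compound 2.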